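This account rests on a few compounds, and the source may have more. Where it says the series, first, only, none or still open, it means among the compounds named here.

Among the measured compounds shown here, the three compounds measured so far share one core and differ only in the group on the amide nitrogen. Compound 1 `CCN(CC)S(=O)(=O)c1ccc(S(=O)(=O)N2CCC[C@@H](C(=O)N[C@@H]3CCN(C(=O)OC(C)(C)C)C3)C2)cc1` carries a 1-(tert-butoxycarbonyl)pyrrolidin-3-yl group there, and in a functional assay on BXPC-3 cells (Homo sapiens) for inhibition, read by MTT assay, with a stated time of 7 days (on this read-out lower numbers stand for stronger inhibition and higher numbers for weaker inhibition), compound 1 gives 400 nM. Compound 2 `CCN(CC)S(=O)(=O)c1ccc(S(=O)(=O)N2CCC[C@@H](C(=O)NC3COC3)C2)cc1` carries oxetan-3-yl; in this assay compound 2 gives 13800 nM. Compound 3 `CCN(CC)S(=O)(=O)c1ccc(S(=O)(=O)N2CCC[C@@H](C(=O)NC3CN(C(=O)NC(C)(C)C)C3)C2)cc1` carries 1-((tert-butyl)carbamoyl)azetidin-3-yl, and in this assay compound 3 gives 10100 nM, the second highest of the three numbers. The steps describe this: a 1.4-fold lower number from compound 2 to compound 3 (0.14 log units; within the scatter), while a 25-fold higher number from compound 1 to compound 3 (1.40 log units; beyond the scatter) and a 35-fold higher number from compound 1 to compound 2 (1.54 log units; beyond the scatter).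

Compound 4 `CCN(CC)S(=O)(=O)c1ccc(S(=O)(=O)N2CCC[C@@H](C(=O)NC3CN(S(C)(=O)=O)C3)C2)cc1` differs from compound 3 in one place: methylsulfonyl in place of (tert-butyl)carbamoyl on an amine nitrogen in a ring. For the measured compounds named here, no measured step alters only the group on the azetidine nitrogen. The two large steps, a 35-fold higher number from compound 1 to compound 2 (1.54 log units; beyond the scatter) and a 25-fold higher number from compound 1 to compound 3 (1.40 log units; beyond the scatter), exchange the whole ring together with its substituent, and the small step of a 1.4-fold lower number from compound 2 to compound 3 (0.14 log units; within the scatter) exchanges the oxetane for the substituted azetidine, so none of them isolates the change at hand. What they show is that two different small rings on the amide nitrogen gave numbers within the scatter of each other. Compound 4 is therefore expected to remain close to compound 3, with a 1.2-fold higher number from compound 3 to compound 4 (0.07 log units; within the scatter) as the expected step. The estimate for compound 4 in this assay is 12000 nM, expected to lie between 4000 nM and 36000 nM.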

Compound 4, half-maximal inhibitory concentration: 7400 nM
Compound 4: middle estimate off by 1.6-fold (0.21 log units), on the high side; the range from low to high includes it.
By their numbers in this assay, from the lowest: compound 1; then compounds 4, 3 and 2 (each within the scatter of the next).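

In this assay, among the compounds shown here, the step of a 1.4-fold lower number from compound 3 to compound 4 (0.14 log units; within the scatter) is the first to alter only the group on an amine nitrogen in a ring, and it shows that methylsulfonyl and (tert-butyl)carbamoyl cannot be told apart at this position, although they differ in heavy atoms, hydrogen-bond donors and hydrogen-bond acceptors. Placing 1-(methylsulfonyl)azetidin-3-yl on the amide nitrogen in place of oxetan-3-yl gives a 1.9-fold lower number from compound 2 to compound 4 (0.27 log units; within the scatter) and so leaves the two groups within the scatter, whereas placing it there in place of 1-(tert-butoxycarbonyl)pyrrolidin-3-yl gives a 19-fold higher number from compound 1 to compound 4 (1.27 log units; beyond the scatter) and leaves compound 1 well apart from the other three compounds. Nothing available gives a reason for either the small or the large steps.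

As far as these compounds go, whether the gap to compound 1 goes with the pyrrolidine ring or with its tert-butoxycarbonyl group remains open. Also open, from the compounds shown here alone, is how the azetidine nitrogen would read with a free amine, an acetyl group or a longer alkyl chain in place of methylsulfonyl.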